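Aryl ketone swap in a two-compound cytotoxicity series

This account rests on a few compounds, and the source may have more. Where it says the series, first, only, none or still open, it means among the compounds named here.

Measured so far in a functional assay on HT-29 cells (Homo sapiens) for cytotoxicity, read by sulforhodamine B assay, with a stated time of 48 h, tested at 1 uM; a higher number here means a weaker effect of the compound at the concentration tested, a lower number a stronger effect:
compound 1 `COc1cc(-c2cc(/C=C/C(=O)c3ccc(N)cc3)[nH]n2)cc(OC)c1OC` gives 82%
compound 2 `COc1ccc(-c2cc(/C=C/C(=O)c3ccc(OC)c(OC)c3)[nH]n2)cc1` gives 77%

Compound 1 holds the higher of the two numbers, but compound 2 sits only a few points away, a gap that lies within the scatter, so the two read alike: both leave most cells unaffected at this concentration. The two also differ in more than one place, so nothing can be assigned to any single change between them.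

Compound 3 `COc1cc(-c2cc(/C=C/C(=O)c3ccc(Cl)c(Cl)c3)[nH]n2)cc(OC)c1OC` is not yet measured. It keeps the shared core of compound 1 and changes one place: 3,4-dichlorophenyl in place of 4-aminophenyl on a carbonyl carbon.

Within the data shown here, with no single-change step available among the measured compounds, the step is expected to stay within the scatter, a number 7 percentage points lower from compound 1 to compound 3 (within the scatter), in either direction. For compound 3 the estimate in this assay is 75%, in the range 50% to 95%.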

Compound 3, a percentage reported as activity, at one concentration (the size of the read-out at that concentration, not a potency): 96%
Beside the measured number, compound 3's estimate is 21 percentage points below it, outside the stated range (above it).
By their numbers in this assay, from the lowest: compounds 2 and 1 (each within the scatter of the next); then compound 3.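

Replacing 4-aminophenyl with 3,4-dichlorophenyl on a carbonyl carbon gives, in this assay, a number 14 percentage points higher from compound 1 to compound 3 (beyond the scatter). Among these compounds, this is the first change that can be read on its own, and it shows that the group at this position can shift the read-out: with the rest of compound 1 held fixed, the effect at the tested concentration is weaker, and compound 3 gives 96%. No measurement at hand explains this step.

As far as these compounds go, whether the step follows the departure of the amine or the entry of the two chlorines stays open; a plain phenyl or a 4-chlorophenyl at the same place on the core of compound 1 would separate the two. Also open, from the compounds shown here alone, is whether the step holds at other concentrations, since this read-out gives no potency.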